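Swapping bromo for acetoxy on the aromatic ring

A few compounds are considered here, and "the series" means these few. Any claim that something is new, unique, unknown or untested is made for them only; others in the source may bear on it.

Measured so far in a functional assay on HGC-27 cells (Homo sapiens) for cytotoxicity, read by MTT assay, with a stated time of 72 h; a higher number here means a weaker inhibitor, a lower number a stronger inhibitor:
- compound 1 `Cc1ccc(/C=C/C=C2\CCC=CC2=O)cc1` gives 8100 nM
- compound 2 `O=C1C=CCC/C1=C\C=C\c1ccc(F)cc1` gives 2300 nM
- compound 3 `O=C1C=CCC/C1=C\C=C\c1ccc(Br)cc1` gives 4500 nM

Compound 3 sits within the usual scatter of both compound 1 and compound 2, so neither pair can be ranked. Compound 4 `CC(=O)Oc1ccc(/C=C/C=C2\CCC=CC2=O)cc1` has acetoxy in place of bromo on an aromatic carbon, para to a large group (acetoxy in place of bromo on an aromatic carbon). Earlier swaps at this place moved the number little. Two stayed within the scatter (a 1.8-fold lower number from compound 1 to compound 3 (0.26 log units; within the scatter) and a 2.0-fold higher number from compound 2 to compound 3 (0.29 log units; within the scatter)), and one went modestly beyond it (a 3.5-fold lower number from compound 1 to compound 2 (0.55 log units; beyond the scatter)). Going by the values given here, no measured compound carries acetoxy, so this guide is rough. The expected step in this assay is a 1.1-fold lower number from compound 3 to compound 4 (0.05 log units; within the scatter) and thus none beyond the scatter. Compound 4 is estimated at 4000 nM (expected range 1500 nM to 11000 nM).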

Compound 4, half-maximal inhibitory concentration: 4900 nM
For compound 4 the middle estimate is 1.2-fold (0.09 log units) below the measured one; measured number inside the range.
By their numbers in this assay, from the lowest: compounds 2, 3, 4 and 1 (each within the scatter of the next, the first and the last beyond it).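

In this assay, acetoxy brings more heavy atoms and hydrogen-bond acceptors than bromo to this aromatic carbon, yet compound 4 cannot be told apart from the bromo or methyl compounds (a 1.1-fold higher number from compound 3 to compound 4 (0.04 log units; within the scatter); a 1.7-fold lower number from compound 1 to compound 4 (0.22 log units; within the scatter)). Only the fluoro compound differs from it, and modestly (a 2.1-fold higher number from compound 2 to compound 4 (0.33 log units; beyond the scatter)). No available evidence accounts for these results. Still open is whether an amine or a carboxylic acid on this aromatic carbon would shift the number further than the groups shown here.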